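Swapping a Fluorophenyl for an Isopropylpyrazole

The source may hold more compounds than are shown below. What is called first, only, known or untested is meant among the compounds shown, and "the series" means these compounds.

Of the compounds shown here, two have been measured in an assay on RAW264.7 cells for inhibition of serine/threonine-protein kinase TBK1 (Mus musculus), read by ELISA, with stated times of 30 min and 6 h; on this read-out higher numbers stand for weaker inhibition and lower numbers for stronger inhibition. Compound 1 `O=C(NCCCNc1nc(Nc2cnn(C3CCOCC3)c2)ncc1C1CC1)C1CCC1` gives 280 nM, while compound 2 `O=C(NCCCNc1nc(Nc2cccc(F)c2)ncc1C1CC1)C1CCC1` gives 1300 nM, the higher of the two numbers and so the weaker inhibitor; this gap lies beyond the scatter of repeated measurements. Compound 3 `CC(C)n1cc(Nc2ncc(C3CC3)c(NCCCNC(=O)C3CCC3)n2)cn1` has not yet been measured. It differs from compound 2 in a single place: 1-isopropyl-1H-pyrazol-4-yl in place of 3-fluorophenyl on a nitrogen on an aromatic ring. Among the measured compounds shown here, no pair of measured compounds shows exactly this exchange, so the expectation leans on compound 1, which gives 280 nM and carries a related heteroaromatic group on the same nitrogen. On that basis a clear improvement is expected, a 4.1-fold lower number from compound 2 to compound 3 (0.61 log units; beyond the scatter), a move beyond the scatter towards stronger inhibition. Compound 3 is estimated at 320 nM in this assay, with a likely range from 110 nM to 950 nM.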

Compound 3, half-maximal inhibitory concentration: 81 nM
For compound 3 the middle estimate is 4.0-fold (0.60 log units) above the measured one, outside the stated range (below it).
By their numbers in this assay, from the lowest: compound 3; then compound 1; then compound 2.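

In this assay, putting 1-isopropyl-1H-pyrazol-4-yl in place of 3-fluorophenyl gives a 16-fold lower number from compound 2 to compound 3 (1.21 log units; beyond the scatter) and so shows directly that this position on the nitrogen responds strongly to the aromatic group it carries. The outer group matters as well, since isopropyl in place of oxan-4-yl on an aromatic nitrogen gives a 3.5-fold lower number from compound 1 to compound 3 (0.54 log units; beyond the scatter) in a smaller but still real step, so the gain does not depend on the five-membered aromatic ring alone. Nothing available explains either step.

As far as these compounds go, it remains open how a methyl group or a piperidin-4-yl group would compare with isopropyl on that aromatic nitrogen. From the compounds shown here alone, it is also open whether the same order of compounds would hold with a longer chain in place of the one that carries the cyclobutane amide.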